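A few compounds are considered here, and "the series" means these few. Any claim that something is new, unique, unknown or untested is made for them only; others in the source may bear on it.

In a functional assay on HCT-116 cells (Homo sapiens) for cytotoxicity, read by MTT assay, with a stated time of 72 h (a higher number here means a weaker inhibitor, a lower number a stronger inhibitor), three compounds with related structures have been measured. Compound 1 `Nc1ccccc1NC(=O)c1ccc(CNC(=O)c2cc3cccnc3[nH]2)cc1` gives 10000 nM, and compound 2 `Nc1ccccc1NC(=O)c1ccc(NC(=S)NCc2ccc(Cl)nc2)cc1` gives 6100 nM. Going by the values given here, these are the only two true numbers available, and they lie within the usual scatter of each other, so compound 2 cannot be separated from compound 1. Compound 3 `Nc1ccccc1NC(=O)c1ccc(Cn2cc(-c3ccc(NC(=O)NCc4cccnc4)cc3)nn2)cc1` is reported with a limit of > 100000 nM, not a number.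

Compound 4 `Nc1ccccc1NC(=O)c1ccc(NC(=S)NCc2cncc(F)c2)cc1` differs from compound 2 in one place: it has 5-fluoropyridin-3-yl in place of 6-chloropyridin-3-yl on a saturated chain carbon bound to an amide-type nitrogen. The rest of the structure stays the same. Among the compounds with values here, no two measured compounds differ in just one place, so the data give no direct guide to the size of such a change. Since a six-membered aromatic ring with one hetero atom is swapped for another of the same kind, no change beyond the scatter is expected in this assay. The estimated step of a 1.1-fold higher number from compound 2 to compound 4 (0.06 log units; within the scatter) is therefore small, and its direction is uncertain. For compound 4 the expected value is 7000 nM, with an estimated range of 2500 nM to 20000 nM.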

Compound 4, half-maximal inhibitory concentration: 15000 nM
Estimate against measurement, compound 4: 2.1-fold (0.33 log units) below, and the stated range covers the measured number.
By their numbers in this assay, from the lowest: compounds 2, 1 and 4 (each within the scatter of the next, the first and the last beyond it). At a limit, above all of these: compound 3.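

In this assay, going by these compounds alone, the swap of 6-chloropyridin-3-yl for 5-fluoropyridin-3-yl gives the first step between two compounds that differ in only one place: a 2.5-fold higher number from compound 2 to compound 4 (0.39 log units; beyond the scatter). It shows that this position, on a saturated chain carbon bound to an amide-type nitrogen, can respond to a change even when one six-membered aromatic ring with one hetero atom replaces another of the same size, although the step is only modest. No measurement shown here bears on why the number rose.

As far as these compounds go, this single swap changes both the halogen and its place on the ring, so the share of each in the step remains open. Also open, from the compounds shown here alone, is how the number would respond if an amine or a carboxylic acid replaced the halogen.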